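The source may hold more compounds than are shown below. What is called first, only, known or untested is meant among the compounds shown, and "the series" means these compounds.

Measured compounds:
- compound 1 `Cc1cccc(Oc2ccnc(N3CCC[C@H]3C(=O)NCCCn3ccnc3)n2)c1`: 0%
- compound 2 `Cc1cccc(N(C)c2cc(Nc3cccc(C(=O)N4CCCC5CCCCC54)c3)ncn2)c1`: 0%

Both compounds were tested in an assay on isolated protein for inhibition of Ephrin type-B receptor 4 (Homo sapiens), read by HTRF, tested at 10 uM; on this read-out lower numbers stand for less inhibition and higher numbers for more inhibition at the one concentration tested (going by the name of the read-out). Compound 1 gives 0% in this assay, and compound 2 gives 0%; the two values sit level with each other within the usual scatter, so neither shows any sign of inhibition at the concentration tested.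

Compound 3 `COC(=O)C(CO)NC(=O)[C@@H]1CCCN1c1nccc(Oc2cccc(C)c2)n1` has not yet been measured. It differs from compound 1 in one place: 2-hydroxy-1-(methoxycarbonyl)ethyl in place of 3-(1H-imidazol-1-yl)propyl on an amide-type nitrogen. The rest of the molecule, including the shared core and the amide carbonyl, is unchanged.

Within the data shown here, with no measured step between any two compounds to guide the size of this change, and with compound 1 showing no inhibition at all, the step is expected to stay within the scatter: a number 2 percentage points higher from compound 1 to compound 3 (within the scatter). Compound 3 is therefore estimated to give 2%, with a plausible range from -8% to 14%.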

Compound 3, a percentage reported as inhibition, at one concentration (the size of the read-out at that concentration, not a potency): 0%
For compound 3 the middle estimate is 2 percentage points above the measured one; the measured number falls inside the stated range.
By their numbers in this assay, from the lowest: compounds 1, 2 and 3 (each within the scatter of the next).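

In this assay, placing 2-hydroxy-1-(methoxycarbonyl)ethyl on the amide-type nitrogen instead of 3-(1H-imidazol-1-yl)propyl gives no change at the digits printed from compound 1 to compound 3 (within the scatter). This is a large exchange, with the five-membered aromatic ring replaced by an open chain with no ring, yet no inhibition appears with either group at the one concentration tested, so neither of these two groups gives this position a readable effect. No supporting measurement is available to explain this result.

With both compounds showing no inhibition, the pair cannot reveal whether a group at this position could weaken inhibition, since there is none to lose. Going by these compounds, it remains open whether a carboxylic acid in place of the methoxycarbonyl, or a primary amine or a longer carbon chain on this nitrogen, would give a measurable number.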